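The source may hold more compounds than are shown below. What is called first, only, known or untested is meant among the compounds shown, and "the series" means these compounds.

Compound 2 `CCCN(CCC)c1cc(C)nc2c(-c3ncc(C)cc3OC)c(C)nn12` is the point of departure. In an assay on isolated protein for binding affinity to corticotropin-releasing factor receptor 1 (Homo sapiens) (a higher number here means a weaker inhibitor, a lower number a stronger inhibitor), compound 2 gives 25 nM. Among the measured compounds shown here, its only measured neighbour, compound 1 `CCCN(CCC)c1cc(C)nc2c(-c3ncc(NC)cc3C)c(C)nn12`, gives 40 nM in this assay, and the step of a 1.6-fold lower number from compound 1 to compound 2 (0.20 log units; within the scatter) is within the scatter, so the two numbers cannot be told apart; compound 2 simply stands at one end of the two values shown.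

Compound 3 `CCCN(CCC)c1cc(C)nc2c(-c3ncc(C)cc3N=O)c(C)nn12` differs from compound 2 by a group of 2 heavy atoms (1 nitrogen, 1 oxygen; no ring) in place of a group of 2 heavy atoms (1 carbon, 1 oxygen; no ring), on an aromatic carbon, on an aromatic carbon of a six-membered aromatic ring with 1 nitrogen, ortho to a large group, two atoms from the ring nitrogen, meta to a methyl group.

For the measured compounds named here, the one measured step, from compound 1 to compound 2, reworked the same ring and stayed within the scatter, which offers no direct precedent for this exchange. He therefore expects only a modest shift, a 2.4-fold higher number from compound 2 to compound 3 (0.38 log units; beyond the scatter), in this assay, and estimates compound 3 at 60 nM, within 20 nM to 180 nM.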

Compound 3, inhibition constant: > 10000 nM
Compound 3 was reported as a limit; the forecaster's own chance of this, stated with the estimate: 5%; middle value at least 160-fold (2.22 log units) from the limit.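

Compound 3 stands only as a limit in this assay: the limit of > 10000 nM in this assay, at which 1 of the 3 values shown sits. Even so, the exchange of methoxy for a group with the same number of heavy atoms, one nitrogen and one oxygen, gives an at least 400-fold higher number from compound 2 to compound 3 (2.60 log units; beyond the scatter), and the comparison with the other neighbour gives an at least 250-fold higher number from compound 1 to compound 3 (2.39 log units; beyond the scatter). Where the earlier step on this ring stayed within the scatter, this result shows that the position, on an aromatic carbon ortho to a large group, does not accept every small group.

The compounds shown compare only methyl, methoxy and this nitrogen-oxygen group here, so what an amine, a hydroxy group or a chlorine atom would give at this position remains open. The reason for the loss also remains open, as does its true size beyond the limit.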